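The source may hold more compounds than are shown below. What is called first, only, known or untested is meant among the compounds shown, and "the series" means these compounds.

Measured so far in a functional assay on MCF7 cells (Homo sapiens) for cytotoxicity, read by MTT assay, with a stated time of 72 h; a higher number here means a weaker inhibitor, a lower number a stronger inhibitor:
- compound 1 `COc1cc(/C=N/NC(=O)Nc2cc3c(Nc4ccc(F)c(Cl)c4)ncnc3cc2O[C@H]2CCOC2)cc(OC)c1OC`: 26500 nM
- compound 2 `O=C(N/N=C/c1ccc(O)cc1O)Nc1cc2c(Nc3ccc(F)c(Cl)c3)ncnc2cc1O[C@H]1CCOC1`: 5350 nM
- compound 3 `O=C(N/N=C/c1ccc(O)cc1)Nc1cc2c(Nc3ccc(F)c(Cl)c3)ncnc2cc1O[C@H]1CCOC1`: 910 nM

Compound 1 stands at the top of the three numbers. Its nearest neighbour is compound 2, reached by a 5.0-fold lower number from compound 1 to compound 2 (0.69 log units; beyond the scatter); its furthest is compound 3, reached by a 29-fold lower number from compound 1 to compound 3 (1.46 log units; beyond the scatter). Between the two hydroxyphenyl compounds the step is a 5.9-fold lower number from compound 2 to compound 3 (0.77 log units; beyond the scatter). All three measured steps alter the aryl group on the carbon with a double bond to nitrogen; none of them touches the oxygen on the aromatic ring of the shared core.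

Compound 4 `COc1cc2ncnc(Nc3ccc(F)c(Cl)c3)c2cc1NC(=O)N/N=C/c1cc(OC)c(OC)c(OC)c1` is the next case. It differs from compound 1 by methyl in place of oxolan-3-yl on an oxygen on an aromatic ring. Among the compounds with values here, no measured step bears on this position, so the series gives no guide to its effect in this assay, and no step beyond the scatter is assumed. Compound 4 is therefore expected to sit near compound 1, with an estimated step of a 1.0-fold lower number from compound 1 to compound 4 (0.01 log units; within the scatter). The estimate for compound 4 in this assay is 26000 nM, within a range of 9000 nM to 75000 nM.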

Compound 4, half-maximal inhibitory concentration: 30700 nM
Estimate against measurement, compound 4: 1.2-fold (0.07 log units) below, within the range that was stated.
By their numbers in this assay, from the lowest: compound 3; then compound 2; then compounds 1 and 4 (each within the scatter of the next).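

In this assay, within the data shown here, the change to methyl in place of oxolan-3-yl on an oxygen on an aromatic ring gives a 1.2-fold higher number from compound 1 to compound 4 (0.06 log units; within the scatter) and is the first step to reach this position. The ring, the ring oxygen and the defined stereocentre of oxolan-3-yl all leave in this one change without a shift beyond the scatter, so with the 3,4,5-trimethoxyphenyl group in place neither of these two groups on the oxygen stands apart from the other. Nothing measured here accounts for this result.

On these data alone, whether the same holds with the 4-hydroxyphenyl group of compound 3 remains open, since the change is read only on the 3,4,5-trimethoxyphenyl compounds. Also open, as far as these compounds go, is how a longer chain ending in an amine or a carboxylic acid on this oxygen would compare with methyl.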